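This account rests on a few compounds, and the source may have more. Where it says the series, first, only, none or still open, it means among the compounds named here.

Three compounds share one core and differ only in the aromatic group attached to the carbonyl carbon of the amide. In a functional assay on HepG2 cells (Homo sapiens) for antiproliferative activity, read by CCK-8 assay, with a stated time of 72 h (on this read-out lower numbers stand for stronger inhibition and higher numbers for weaker inhibition), compound 1 `O=C(Nc1cccc(-c2oc3cc(-c4ccc(F)cc4)ccc3c(=O)c2O)c1)c1ccccc1F` gives 10100 nM. In this assay compound 2 `COc1ccc(C(=O)Nc2cccc(-c3oc4cc(-c5ccc(F)cc5)ccc4c(=O)c3O)c2)cc1` gives 8420 nM, and compound 3 `O=C(Nc1cccc(-c2oc3cc(-c4ccc(F)cc4)ccc3c(=O)c2O)c1)c1ccc(Cl)cc1` gives 11000 nM. On these numbers compound 3 carries the highest reading of the three, yet both gaps are small: a 1.1-fold higher number from compound 1 to compound 3 (0.04 log units; within the scatter) and a 1.3-fold higher number from compound 2 to compound 3 (0.12 log units; within the scatter). The third step, a 1.2-fold lower number from compound 1 to compound 2 (0.08 log units; within the scatter), is equally slight.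

Compound 4 `O=C(Nc1cccc(-c2oc3cc(-c4ccc(F)cc4)ccc3c(=O)c2O)c1)c1ccc(F)cc1F` is the next variation of the same kind: 2,4-difluorophenyl in place of 4-chlorophenyl on a carbonyl carbon. Every step measured so far changed this same aromatic group on the carbonyl carbon, and none of them moved the number beyond the scatter, whether a fluorine, a methoxy or a chlorine was carried on that ring. There is no measured case of two fluorines on this ring, so the expectation rests on the three swaps already seen. On that basis no step beyond the scatter is expected from compound 3 to compound 4 in this assay; the estimated step is a 1.1-fold lower number from compound 3 to compound 4 (0.04 log units; within the scatter). Compound 4 is therefore expected to give about 10000 nM, with a range from 5000 nM to 20000 nM.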

Compound 4, half-maximal inhibitory concentration: 26400 nM
Beside the measured number, compound 4's estimate is 2.6-fold (0.42 log units) below it; measured number above the stated range.
By their numbers in this assay, from the lowest: compounds 2, 1 and 3 (each within the scatter of the next); then compound 4.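

In this assay, the aromatic group on the carbonyl carbon turns out not to be indifferent to change, as the first three compounds had suggested: swapping 4-chlorophenyl for 2,4-difluorophenyl gives a 2.4-fold higher number from compound 3 to compound 4 (0.38 log units; beyond the scatter) and replacing the methoxy-bearing ring gives a 3.1-fold higher number from compound 2 to compound 4 (0.50 log units; beyond the scatter) on the same read-out. The most telling change is the smallest one, fluoro in place of hydrogen on an aromatic carbon, which gives a 2.6-fold higher number from compound 1 to compound 4 (0.42 log units; beyond the scatter) and so shows that one added fluorine is enough to weaken the reading modestly, making compound 4 the weakest of the four. What lies behind this shift cannot be said, as nothing beyond these cell readings is available to explain it.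

Among these compounds, compound 4 is the only compound here with two groups on this ring, so it remains open whether the higher number belongs to fluorine itself or to having two groups of any kind. A ring carrying two chlorines or two methoxy groups would help separate those readings, and an amine or a carboxylic acid on the ring would test whether this tolerance extends to quite different groups.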